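A few compounds are considered here, and "the series" means these few. Any claim that something is new, unique, unknown or untested is made for them only; others in the source may bear on it.

Three compounds that share one core were tested in an ADME assay on L929 cells (Mus musculus) for cytotoxicity, read by resazurin assay, with a stated time of 72 h; on this read-out lower numbers stand for stronger inhibition and higher numbers for weaker inhibition. Compound 1 `OB1OCc2ccc(-n3ccc4ccccc43)cc21` gives only a limit of the test, > 10 ug/mL. Compound 2 `CNC(=O)c1cccn1-c1ccc2c(c1)B(O)OC2` likewise gives only a limit, > 10 ug/mL. Compound 3 `O=C(c1ccccc1)c1ccn(-c2ccc3c(c2)B(O)OC3)c1` also gives only a limit, > 10 ug/mL. Where compound 3 stands is therefore known only through (the limit of > 10 ug/mL in this assay, at which 3 of the 3 values shown sit). Compound 4 `CCc1ccc(C(=O)c2ccn(-c3ccc4c(c3)B(O)OC4)c2)cc1` is still to be measured in this assay. Compound 4 differs from compound 3 by ethyl in place of hydrogen on an aromatic carbon. Because the limit of > 10 ug/mL in this assay, at which 3 of the 3 values shown sit, is all the shown values give, nothing points to a change in either direction, and no step beyond the scatter is expected. The expected step is a step that the limit leaves unreadable from compound 3 to compound 4. Compound 4 is thus estimated at 15 ug/mL, between 7 ug/mL and 40 ug/mL.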

Compound 4, half-maximal inhibitory concentration: > 10 ug/mL
Compound 4 gave a limit, no number (the forecaster's own chance of this, stated with the estimate: 75%); the middle value lies beyond the limit too.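

No step can be read from compound 3 to compound 4, since both results are only limits of the test: the limit of > 10 ug/mL in this assay, at which 4 of the 4 values shown sit.

Left open is whether the ethyl group changes the result in this assay at all, and what actual number any of the four compounds would give.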